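A Nitrile Replaces a Hydroxymethyl on a Shared Core

The source may report more compounds than this note shows. Statements on the series, on what has been measured and on what is new or still open speak of the compounds shown alone.

Of the compounds shown here, three sharing one core have been measured in an assay on CHO cells for displacement of a labelled ligand from adenosine receptor A1 (Homo sapiens), read by scintillation counting, with a stated time of 3 h; a higher number here means a weaker inhibitor, a lower number a stronger inhibitor. Compound 1 `N#Cc1cccc(-c2nc(N)c3nc(-c4ccccc4)sc3n2)c1` gives 594 nM. Compound 2 `Nc1nc(-c2ccccc2)nc2sc(-c3ccco3)nc12` gives 33 nM, and compound 3 `Nc1nc(-c2cccc(CO)c2)nc2sc(-c3ccco3)nc12` gives 28 nM, the lowest number of the three, though its gap to compound 2 is within the scatter. Among the measured compounds shown here, the only measured step, a 1.2-fold lower number from compound 2 to compound 3 (0.07 log units; within the scatter), is likewise within the scatter. Compound 4 `N#Cc1cccc(-c2nc(N)c3nc(-c4ccco4)sc3n2)c1` is compound 3 with cyano in place of hydroxymethyl on an aromatic carbon. For the measured compounds named here, no measured step isolates this exchange. Compound 1 carries the same cyano group but differs from compound 2 at a second place as well; compound 1 gives 594 nM while compound 2 gives 33 nM, a much higher number for the cyano-bearing compound. Weighing this, compound 4 is expected to give 150 nM, between 40 nM and 600 nM, an expected step of a 5.4-fold higher number from compound 3 to compound 4 (0.73 log units; beyond the scatter) in this assay.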

Compound 4, inhibition constant: 103 nM
Beside the measured number, compound 4's estimate is 1.5-fold (0.16 log units) above it; the measured number falls inside the stated range.
By their numbers in this assay, from the lowest: compounds 3 and 2 (each within the scatter of the next); then compound 4; then compound 1.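

With furan-2-yl held fixed, swapping hydroxymethyl for cyano at this position has a measurable effect (a 3.7-fold higher number from compound 3 to compound 4 (0.57 log units; beyond the scatter)), whereas hydroxymethyl in place of hydrogen stayed within the scatter. Cyano in place of hydrogen also raises the number (a 3.1-fold higher number from compound 2 to compound 4 (0.49 log units; beyond the scatter)), so the rise goes with cyano's presence and not only with hydroxymethyl's loss. With cyano kept, furan-2-yl in place of phenyl lowers the number (a 5.8-fold lower number from compound 1 to compound 4 (0.76 log units; beyond the scatter)), so the other place matters too.

Nothing shown explains these shifts. From the compounds shown here alone, how an amine or a carboxylic acid would behave at this position remains open.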